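Swapping the pyrazole substituent on a shared amide core

This account rests on a few compounds, and the source may have more. Where it says the series, first, only, none or still open, it means among the compounds named here.

Compound 1 `CNC(=O)N1CCCc2ccc(NC(=O)c3ccc(-c4ccccc4)cc3)cc21` gives 19.7% in a functional assay on MV4-11 cells (Homo sapiens) for antiproliferative activity, with a stated time of 6 days, tested at 1.56 uM; a lower number here means a weaker effect, a higher number a stronger effect of the compound at the concentration tested.
Compound 2 `CNC(=O)N1CCCc2ccc(NC(=O)c3ccc(-c4cnn(C)c4)cc3)cc21` gives 77.4% in this assay.
Compound 3 `CNC(=O)N1CCCc2ccc(NC(=O)c3ccc(-c4ccn(S(C)(=O)=O)n4)cc3)cc21` gives 8.81% in this assay.

Compound 3 stands lowest of the three measured compounds in this assay: compound 1 lies a number 10.9 percentage points lower from compound 1 to compound 3 (beyond the scatter), and compound 2 lies a number 68.6 percentage points lower from compound 2 to compound 3 (beyond the scatter). Compound 4 `CNC(=O)N1CCCc2ccc(NC(=O)c3ccc(-c4cnn(C(C)=O)c4)cc3)cc21` is the next compound to be measured. It differs from compound 3 in one place: 1-acetyl-1H-pyrazol-4-yl in place of 1-(methylsulfonyl)-1H-pyrazol-3-yl on an aromatic carbon.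

Going by the values given here, two measured steps bear on this change. The step of a number 68.6 percentage points lower from compound 2 to compound 3 (beyond the scatter) shows how much was lost when a 1-methyl-1H-pyrazol-4-yl gave way to a 1-(methylsulfonyl)-1H-pyrazol-3-yl. The step of a number 57.7 percentage points higher from compound 1 to compound 2 (beyond the scatter) shows how much the 1-methyl-1H-pyrazol-4-yl gained over plain phenyl. Compound 4 carries a pyrazol-4-yl like compound 2, but with an acetyl on the ring nitrogen rather than a methyl, so only part of that gain is expected to return. Among the compounds with values here, the estimated step is a number 36.2 percentage points higher from compound 3 to compound 4 (beyond the scatter) in this assay, upward and beyond the scatter, with a wide range because no measured compound carries an acetyl. Compound 4 is expected to give 45%, between 12% and 78%.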

Compound 4, a percentage reported as inhibition, at one concentration (the size of the read-out at that concentration, not a potency): 23.9%
Compound 4: middle estimate off by 21.1 percentage points, on the high side; the range from low to high includes it.
By their numbers in this assay, from the lowest: compound 3; then compounds 1 and 4 (each within the scatter of the next); then compound 2.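

The methyl on the ring nitrogen of the pyrazol-4-yl matters: acetyl in its place gives a number 53.5 percentage points lower from compound 2 to compound 4 (beyond the scatter) and removes most of what compound 2 had gained. A pyrazol-4-yl ring alone therefore does not secure a high number, since replacing phenyl with the 1-acetyl-1H-pyrazol-4-yl gives a number 4.2 percentage points higher from compound 1 to compound 4 (within the scatter) and leaves the two compounds level. The 1-acetyl-1H-pyrazol-4-yl recovers only a little over the 1-(methylsulfonyl)-1H-pyrazol-3-yl, with a number 15.1 percentage points higher from compound 3 to compound 4 (beyond the scatter) as the step, and that change alters both the nitrogen substituent and the ring's attachment point.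

On these data alone, it remains open whether an ethyl, a propyl or a chain ending in an amine on that nitrogen would keep the level of compound 2. No supporting data explain why acetyl falls so far below methyl.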